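A few compounds are considered here, and "the series" means these few. Any claim that something is new, unique, unknown or untested is made for them only; others in the source may bear on it.

Three compounds share a core and differ in the group on the aromatic ring: compound 1 `CCOC(=O)c1cnc(-c2ccccc2[N+](=O)[O-])[nH]c1=O`, compound 2 `CCOC(=O)c1cnc(-c2ccccc2OCC)[nH]c1=O` and compound 3 `CCCCOc1ccccc1-c1ncc(C(=O)OCC)c(=O)[nH]1`. In a functional assay on the whole organism (strain Sprague-Dawley) for inhibition, with Rattus norvegicus as the target, with a stated time of 10 min (a lower number here means that less compound is needed, a higher number that more compound is needed for the effect), compound 1 has no numerical result, recorded as "not determined" (no result reported), while compound 2 gives 2 mg/kg and compound 3 gives 0.5 mg/kg. Compound 3 therefore holds the lower of the two numbers available.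

The next compound, compound 4 `CCOC(=O)c1cnc(-c2ccccc2OCC(C)C)[nH]c1=O`, has the same atoms as compound 3, joined differently. Butoxy becomes isobutoxy, which means isopropyl in place of propyl on a saturated chain carbon bound to an oxygen on an aromatic ring.

For the measured compounds named here, only one measured step bears on this change: a 4.0-fold lower number from compound 2 to compound 3 (0.60 log units; beyond the scatter). That modest step lay beyond the scatter, but it lengthened the chain, with ethyl in place of hydrogen. Going by the values given here, the new change leaves the atoms as they are and only branches the chain, and no measured pair shows what branching does. A step of the earlier size is therefore not expected in this assay. The expected change is a 1.4-fold higher number from compound 3 to compound 4 (0.15 log units; within the scatter), which stays within the scatter. For compound 4, the estimated value is 0.7 mg/kg, with an expected range of 0.2 mg/kg to 2.5 mg/kg.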

Compound 4, dose for 50% inhibition: 3 mg/kg
Compound 4: middle estimate off by 4.3-fold (0.63 log units), on the low side; the measured number lies above the stated range.
By their numbers in this assay, from the lowest: compound 3; then compounds 2 and 4 (each within the scatter of the next).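

In this assay, the shape of the chain at this place proves to matter as well as its length: with the atoms unchanged, butoxy to isobutoxy gives a 6.0-fold higher number from compound 3 to compound 4 (0.78 log units; beyond the scatter), a step beyond the scatter that runs opposite to the earlier 4.0-fold lower number from compound 2 to compound 3 (0.60 log units; beyond the scatter). The gain seen with butoxy is therefore not kept by every chain of that size, and the isobutoxy compound falls back to the level of the ethoxy compound, with a 1.5-fold higher number from compound 2 to compound 4 (0.18 log units; within the scatter), a difference that stays within the scatter. Nothing measured here explains why branching has this effect.

As far as these compounds go, it remains open whether a longer chain, such as pentyl in place of butyl, would continue the trend from ethoxy to butoxy, and whether branching would have the same effect on a chain of another length. From the compounds shown here alone, it is also open how an amine or a carboxylic acid on the chain would compare, and compound 1, recorded as "not determined" (no result reported), offers no numerical comparison for a group other than an alkoxy chain.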